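This account rests on a few compounds, and the source may have more. Where it says the series, first, only, none or still open, it means among the compounds named here.

Compound 3 `CNc1ncc2c(-c3ccc(N4CCN(C)CC4)nc3)nn(CC3CCCC3)c2n1` gives 3670 nM in an assay for inhibition of tyrosine-protein kinase receptor TYRO3 (Homo sapiens), read by 33P incorporation, in the presence of a further agent that is not named here (on this read-out higher numbers stand for weaker inhibition and lower numbers for stronger inhibition), the higher of the two numbers in hand; compound 2 `CCN1CCN(c2ccc(-c3nn(Cc4cn(Cc5ccccc5)nn4)c4nc(NC)ncc34)cn2)CC1` gives 1900 nM, a gap that stays within the scatter. Compound 1 `CNc1ncc2c(-c3ccc(N4CCNCC4)nc3)nn(CC3CCCC3)c2n1` reaches only the limit of > 10000 nM in this assay. The step of an at least 2.7-fold lower number from compound 1 to compound 3 (0.43 log units; beyond the scatter) is therefore read against the limit (the limit of > 10000 nM in this assay, at which 1 of the 3 values shown sits). Compound 4 `CCN1CCN(c2ccc(-c3nn(CC4CCCC4)c4nc(NC)ncc34)cn2)CC1` differs from compound 3 by methyl in place of hydrogen on a saturated chain carbon bound to an amine nitrogen in a ring. Among the measured compounds shown here, no measured step touches this place; the one step in hand concerns the ring nitrogen itself, and compound 2, which carries the ethyl group, differs elsewhere as well. For compound 4 the expected step of a 1.3-fold lower number from compound 3 to compound 4 (0.12 log units; within the scatter) is none beyond the scatter. Compound 4 is estimated at 2800 nM, between 1100 nM and 7500 nM.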

Compound 4, half-maximal inhibitory concentration: > 10000 nM
Compound 4: no number, only a limit (the forecaster's own chance of this, stated with the estimate: 10%); middle value at least 3.5-fold (0.55 log units) away from the limit.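

The change from 4-methylpiperazin-1-yl to 4-ethylpiperazin-1-yl weakens inhibition in this assay, with an at least 2.7-fold higher number from compound 3 to compound 4 (0.43 log units; beyond the scatter), so the gain from methyl on the ring nitrogen does not extend to ethyl with cyclopentyl in place. With the ethyl group held, cyclopentyl in place of 1-benzyl-1H-1,2,3-triazol-4-yl gives an at least 5.2-fold higher number from compound 2 to compound 4 (0.72 log units; beyond the scatter), so the reading for the ethyl group depends on that second place. Compound 4 stands at a limit, and the step from compound 1 to it cannot be read: the limit of > 10000 nM in this assay, at which 2 of the 4 values shown sit.

Open, from the compounds shown here alone, is how a propyl or 2-hydroxyethyl group on this ring nitrogen would read. Also open, going by these compounds, is how the methyl group would read with 1-benzyl-1H-1,2,3-triazol-4-yl in place of cyclopentyl.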